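Aryl exchange on the ring amine of the aminothiophene ketone series

A few compounds are considered here, and "the series" means these few. Any claim that something is new, unique, unknown or untested is made for them only; others in the source may bear on it.

Two compounds of the series have numbers in a functional assay on CHO cells with adenosine receptor A1 (Homo sapiens) as the target, read by cAMP accumulation and immunoassay, with a stated time of 6 min, tested at 0.01 uM; a higher number here means a weaker effect of the compound at the concentration tested, a lower number a stronger effect: compound 1 `Nc1scc(CN2CCN(c3cccc(Cl)c3Cl)CC2)c1C(=O)c1ccc(Cl)cc1` and compound 2 `Nc1scc(CN2CCN(c3cccc(C(F)(F)F)c3)CC2)c1C(=O)c1ccc(Cl)cc1`. Compound 1 gives 1% in this assay, and compound 2 gives -8.2%. The only step between measured compounds is a number 9.2 percentage points lower from compound 1 to compound 2 (within the scatter), so the two numbers shown cannot be told apart, and compound 2 stands beside compound 1 rather than away from it; both lie close to no effect at the concentration tested.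

Compound 3 `Nc1scc(CN2CCN(c3cccnc3)CC2)c1C(=O)c1ccc(Cl)cc1` is not yet measured. It differs from compound 2 by pyridin-3-yl in place of 3-(trifluoromethyl)phenyl on an amine nitrogen in a ring. Among the measured compounds shown here, the one measured step that bears on this place, the exchange of one aromatic group for another on the same ring nitrogen, is a number 9.2 percentage points lower from compound 1 to compound 2 (within the scatter), and it stayed within the scatter. For the measured compounds named here, no step to a ring with a hetero atom is available, so the expectation rests on the two numbers alone. For compound 3 the expected step in this assay is a number 5.2 percentage points higher from compound 2 to compound 3 (within the scatter), that is, none beyond the scatter. Compound 3 is therefore estimated to give -3%, with a range from -18% to 12%.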

Compound 3, a percentage reported as activity, at one concentration (the size of the read-out at that concentration, not a potency): 3.2%
Estimate against measurement, compound 3: 6.2 percentage points below, and the stated range covers the measured number.
By their numbers in this assay, from the lowest: compounds 2, 1 and 3 (each within the scatter of the next, the first and the last beyond it).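

Among the compounds shown here, the exchange of 3-(trifluoromethyl)phenyl for pyridin-3-yl gives the first step on this ring nitrogen that clears the scatter in this assay: a number 11.4 percentage points higher from compound 2 to compound 3 (beyond the scatter) is modest, but it shows that a change of aromatic group at this place can register, and it is also the first reading of a ring with a hetero atom here. The same group set against 2,3-dichlorophenyl gives a number 2.2 percentage points higher from compound 1 to compound 3 (within the scatter) and so cannot be told apart from it, which means that the separation holds only against the 3-(trifluoromethyl)phenyl compound and not against the whole set. No measurement at hand bears on the reason for this difference.

Whether the position of the ring nitrogen matters remains open, since pyridin-2-yl and pyridin-4-yl are not among the compounds shown, and a non-aromatic group such as cyclohexyl on the same ring nitrogen is also untested in the compounds shown. With only one concentration shown, the numbers also leave open whether the modest step would persist at higher concentrations, where a larger effect could separate these compounds more clearly.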